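Hydrazone series on a nitro benzimidazole core: furan to tolyl

The source may report more compounds than this note shows. Statements on the series, on what has been measured and on what is new or still open speak of the compounds shown alone.

Measured so far:
compound 1 `CC(C)=NNC(=O)c1cc2nc(C)[nH]c2cc1[N+](=O)[O-]`
compound 2 `Cc1nc2cc(C(=O)N/N=C\c3ccc(C)o3)c([N+](=O)[O-])cc2[nH]1`

In a functional assay on A549 cells (Homo sapiens) for cytotoxicity, read by resazurin assay, with a stated time of 72 h (on this read-out lower numbers stand for stronger inhibition and higher numbers for weaker inhibition), compound 1 gives > 100000 nM, which is a limit of the assay and not a number. In this assay compound 2 gives > 100000 nM, likewise a limit. Going by the values given here, the one measured step, a step that the two limits leave unreadable from compound 1 to compound 2, therefore cannot be read in size or direction. Both values shown sit at the same limit (the limit of > 100000 nM in this assay, at which 2 of the 2 values shown sit).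

Compound 2 thus stands at the limit, with no number beneath it; the same is true of compound 1, so no ranking between them follows.

Compound 3 `Cc1ccc(/C=N\NC(=O)c2cc3nc(C)[nH]c3cc2[N+](=O)[O-])cc1` is not yet measured. It differs from compound 2 by 4-methylphenyl in place of 5-methylfuran-2-yl on a carbon with a double bond to nitrogen. No measured step bears on an exchange of one aromatic ring for another on the carbon with a double bond to nitrogen; the only step shown, from compound 1 to compound 2, is itself unreadable. Since both measured values are limits, the expectation for compound 3 is a value around the same limit, 100000 nM with range 30000 nM to 300000 nM, and the expected step of a number no higher from compound 2 to compound 3 (the limit leaves the size open) is none beyond the scatter.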

Compound 3, half-maximal inhibitory concentration: 73000 nM
Compound 3: middle estimate off by 1.4-fold (0.14 log units), on the high side; the measured number falls inside the stated range.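

In this assay, going by these compounds alone, compound 3, with 4-methylphenyl on the carbon with a double bond to nitrogen, gives 73000 nM, the first value in these notes that is a number and not a limit. Within the data shown here, the exchange of 5-methylfuran-2-yl for 4-methylphenyl at this carbon gives an at least 1.3-fold lower number from compound 2 to compound 3 (0.13 log units; that floor lies within the scatter), so the printed floor of the step does not by itself separate the two compounds, and the step shows only that a number can be reached with a six-membered aromatic ring of carbon only at this place. The other two compounds remain at a limit of the assay, not a number: the limit of > 100000 nM in this assay, at which 2 of the 3 values shown sit.

On these data alone, the true size of the step to compound 3 stays open, and the step from compound 1 to compound 2 cannot be read at all. Also open, as far as these compounds go, is whether an amine or a carboxylic acid in place of the methyl of 4-methylphenyl, or a longer chain in place of the whole ring, would move the number beyond the usual scatter.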